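The compounds below may be only part of what the source reports. "The series", "measured", "known", "first", "only" and "open" are said of these compounds alone.

Compound 1 `COc1cc(-c2nnc3n2NC(c2ccco2)C(C(=O)c2ccc(F)c(F)c2)S3)cc(OC)c1OC` carries a (3,4-difluorophenyl)carbonyl on the shared core and, in a functional assay on A549 cells (Homo sapiens) for cytotoxicity, read by MTT assay, with a stated time of 48 h (a lower number here means a stronger inhibitor, a higher number a weaker inhibitor), compound 1 gives 93700 nM, the highest of the three numbers measured. Compound 2 `COc1cc(-c2nnc3n2NC(c2ccco2)C(C(=O)c2ccco2)S3)cc(OC)c1OC` bears a furan-2-yl on that carbonyl carbon and gives 68700 nM; compound 3 `COc1cc(-c2nnc3n2NC(c2ccco2)C(C(=O)c2ccccc2)S3)cc(OC)c1OC` bears a phenyl there and gives 33400 nM. The change a 1.4-fold lower number from compound 1 to compound 2 (0.13 log units; within the scatter), whereas a 2.8-fold lower number from compound 1 to compound 3 (0.45 log units; beyond the scatter) and a 2.1-fold lower number from compound 2 to compound 3 (0.31 log units; beyond the scatter). Compound 4 `COc1cc(-c2nnc3n2NC(c2ccco2)C(C(=O)c2ccc(F)cc2)S3)cc(OC)c1OC` differs from compound 1 by hydrogen in place of fluoro on an aromatic carbon, so it sits part way along the change from compound 1 to compound 3. Because of the step of a 2.8-fold lower number from compound 1 to compound 3 (0.45 log units; beyond the scatter) a smaller move in the same direction is expected for compound 4, a 1.6-fold lower number from compound 1 to compound 4 (0.19 log units; within the scatter), which may not exceed the scatter. Compound 4 is therefore estimated at 60000 nM, with a range from 30000 nM to 120000 nM.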

Compound 4, half-maximal inhibitory concentration: 53700 nM
For compound 4 the middle estimate is 1.1-fold (0.05 log units) above the measured one; the range from low to high includes it.
By their numbers in this assay, from the lowest: compounds 3, 4, 2 and 1 (each within the scatter of the next, the first and the last beyond it).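

In this assay, going by these compounds alone, the single fluoro swap from 3,4-difluorophenyl to 4-fluorophenyl stays within the scatter (a 1.7-fold lower number from compound 1 to compound 4 (0.24 log units; within the scatter)), and so does the step that removes the remaining fluoro (a 1.6-fold higher number from compound 3 to compound 4 (0.21 log units; within the scatter)). The gap between compound 1 and compound 3 therefore exceeds the scatter only when both fluoro groups are gone. The 4-fluorophenyl group is also not separated from furan-2-yl (a 1.3-fold lower number from compound 2 to compound 4 (0.11 log units; within the scatter)). On these data alone, whether an amine or a carboxylic acid on this ring would shift the number remains open. No measurement offered here explains these steps.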